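Tolerance of a Dimethoxyphenyl Variant in HeLa Cells

This account rests on a few compounds, and the source may have more. Where it says the series, first, only, none or still open, it means among the compounds named here.

Compound 1, `CSc1nc(NCCCCNc2ccnc3cc(Cl)ccc23)c(C#N)c(-c2ccccc2)n1`: 100000 nM
Compound 2, `CSc1nc(OCCCNc2ccnc3cc(Cl)ccc23)c(C#N)c(-c2ccccc2)n1`: 4000 nM
Compound 3, `CSc1nc(-c2ccccc2)c(C#N)c(N2CCN(c3ccnc4cc(Cl)ccc34)CC2)n1`: > 100000 nM

Three compounds sharing the core of compound 1 were tested in an ADME assay on HeLa cells (Homo sapiens) for cytotoxicity, read by microscopy; a lower number here means that less compound is tolerated, a higher number that more compound is tolerated. Compound 1 gives 100000 nM and stands highest of the two numbers reported. The nearest number belongs to compound 2, which gives 4000 nM in this assay, a gap well beyond the usual scatter. Compound 3 reports only > 100000 nM, which is a limit of the assay and not a number, (the limit of > 100000 nM in this assay, at which 1 of the 3 values shown sits).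

The compound not yet measured, compound 4, `COc1ccc(-c2nc(SC)nc(NCCCCNc3ccnc4cc(Cl)ccc34)c2C#N)cc1OC`, differs from compound 1 in one place: 3,4-dimethoxyphenyl in place of phenyl on an aromatic carbon. Among the measured compounds shown here, no step between two measured compounds touches this part of the core, so there is no measured guide to its effect. Among the measured compounds, the two that keep the four-carbon chain of compound 1 or close the chain into a ring sit at or near the top of the range, which suggests the shared core is tolerated at high concentration.

From compound 1 the step of a 1.4-fold lower number from compound 1 to compound 4 (0.15 log units; within the scatter) is expected to be small, none beyond the scatter or at most a slight decrease. Compound 4 is therefore estimated at 70000 nM, with a range from 20000 nM to 100000 nM.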

Compound 4, minimum cytotoxic concentration: 100000 nM
Beside the measured number, compound 4's estimate is 1.4-fold (0.15 log units) below it; measured number inside the range.
By their numbers in this assay, from the lowest: compound 2; then compounds 1 and 4 (each within the scatter of the next).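

In this assay, replacing phenyl with 3,4-dimethoxyphenyl gives no change at the digits printed from compound 1 to compound 4 (within the scatter), and this is the first step shown that touches this position. It shows that this aromatic carbon, ortho to a cyano group and next to the ring nitrogen, can carry the larger 3,4-dimethoxyphenyl, with its hydrogen-bond acceptors that phenyl lacks, and that the numbers for the two compounds lie within the scatter of each other. Nothing measured here gives a reason for this outcome.

On these data alone, it remains open whether the same holds for a single methoxy group, for a chlorine atom, an amine or a carboxylic acid on this phenyl, or for a saturated ring such as cyclohexyl in its place. Among the compounds shown here, also open is whether 3,4-dimethoxyphenyl would have the same lack of effect on the oxygen-linked chain of compound 2, which gives 4000 nM, since the only step at this position was read on the four-carbon chain of compound 1.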